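The compounds below may be only part of what the source reports. "The series", "measured", "known", "first", "only" and "open" are said of these compounds alone.

Compound 2 `CNC(=O)NC[C@H]1O[C@@H](n2cnc3c(NC(=O)Nc4ccccc4)ncnc32)[C@H](O[Si](C)(C)C(C)(C)C)[C@@H]1CC(=O)N(C)OC` and compound 1 `CCOC(=O)C[C@H]1[C@@H](O[Si](C)(C)C(C)(C)C)[C@H](n2cnc3c(NC(=O)Nc4ccccc4)ncnc32)O[C@@H]1COC(=O)NC` were both tested in a functional assay on U-251 cells (Homo sapiens) for antiproliferative activity; on this read-out higher numbers stand for weaker inhibition of growth and lower numbers for stronger inhibition of growth. In this assay compound 2 gives 5.66 nM, and compound 1 gives 7.57 nM; the two numbers lie within the usual scatter of each other, so neither stands apart from the other on this read-out. Compound 3 `CCOC(=O)C[C@H]1[C@@H](O[Si](C)(C)C(C)(C)C)[C@H](n2cnc3c(NC(=O)Nc4ccccc4)ncnc32)O[C@@H]1CNC(=O)NC` has not yet been measured. It differs from compound 2 in one place, ethoxy in place of methoxy(methyl)amino on a carbonyl carbon: a methoxy(methyl)carbamoyl)methyl group becomes an (ethoxycarbonyl)methyl group on a saturated chain carbon. Compound 1 already carries the ethoxycarbonyl group, and its value in this assay does not separate from that of compound 2, so no step beyond the scatter is expected here. The step from compound 2 to compound 3 is estimated as a 1.2-fold higher number from compound 2 to compound 3 (0.09 log units; within the scatter). For compound 3 the estimated value in this assay is 7 nM, expected to fall between 3.5 nM and 14 nM.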

Compound 3, concentration for 50% growth inhibition: 4.69 nM
Estimate against measurement, compound 3: 1.5-fold (0.17 log units) above, within the range that was stated.
By their numbers in this assay, from the lowest: compounds 3, 2 and 1 (each within the scatter of the next).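

In this assay, ethoxy in place of methoxy(methyl)amino on a carbonyl carbon gives a 1.2-fold lower number from compound 2 to compound 3 (0.08 log units; within the scatter), a direct reading of this single change, and it does not separate compound 2 from compound 3. A second change, (methylcarbamoyl)amino in place of (methylcarbamoyl)oxy on a saturated chain carbon bound to a saturated ring carbon, gives a 1.6-fold lower number from compound 1 to compound 3 (0.21 log units; within the scatter), so this exchange does not separate its pair on this read-out either. Nothing measured here bears on why these values stay so close.

Both groups on the carbonyl carbon are of similar size, so a carboxylic acid or a longer chain such as butoxy there remains an open test of this position. All three compounds also carry the same silyl ether, which leaves open how a free hydroxyl in its place would read.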